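A few compounds are considered here, and "the series" means these few. Any claim that something is new, unique, unknown or untested is made for them only; others in the source may bear on it.

The series starts from compound 1 `COc1cccc(N2CCN(C(=O)C(C)N3C(=O)CCC3=O)CC2)c1`, which in a functional assay on the whole organism (strain Swiss) with Mus musculus as the target, in the maximal electroshock model, with a stated time of 0.5 h, at a dose of 100 mg/kg by the intraperitoneal route (a higher number here means a stronger effect of the compound at the dose given, a lower number a weaker effect), gives 0%. Compound 2 `CC(C(=O)N1CCN(c2ccccc2)CC1)N1C(=O)CCC1=O` differs from it only by hydrogen in place of methoxy on an aromatic carbon, and in this assay compound 2 gives 0%. The step of no change at the digits printed from compound 1 to compound 2 (within the scatter) shows that the change on the aromatic ring left the read-out where it was, so compound 2 stands level with compound 1 on the numbers available, and neither compound shows any effect at the dose used.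

Compound 3 `CCC(C(=O)N1CCN(c2ccccc2)CC1)N1C(=O)CCC1=O` is the next member and has not yet been measured. It differs from compound 2 as follows: methyl in place of hydrogen on a saturated chain carbon, two bonds along the chain from an amide-type nitrogen in a ring and a carbonyl carbon. Put another way, the difference cut one bond further out reads methyl to ethyl. Within the data shown here, no measured step touches this saturated chain carbon; the single step available, from compound 1 to compound 2, concerns the aromatic ring and was flat. Among the measured compounds shown here, with both measured compounds inactive and no step of any size to build on, the estimated step of no change at the digits printed from compound 2 to compound 3 (within the scatter) is none beyond the scatter. Compound 3 is therefore expected to give 0%, with a range from 0% to 25%.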

Compound 3, a percentage reported as activity, at one dose (the size of the read-out at that dose, not a potency): 25%
Compound 3: the middle estimate sits 25 percentage points below what was measured, and the stated range covers the measured number.
By their numbers in this assay, from the lowest: compounds 1 and 2 (each within the scatter of the next); then compound 3.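

Among these compounds, the saturated chain carbon, two bonds along the chain from an amide-type nitrogen in a ring and a carbonyl carbon, proves to be a place where this assay responds: methyl in place of hydrogen there gives a number 25 percentage points higher from compound 2 to compound 3 (beyond the scatter) and not the flat result seen for the only earlier step, which lay on the aromatic ring. Among the compounds shown here, this is the first step beyond the scatter, and it turns an inactive compound into one with a modest read-out through nothing more than a change from methyl to ethyl on the chain, with the rest of the structure kept. Nothing available explains why this change raises the read-out.

The compounds shown leave open whether a longer chain such as propyl, or a branched one such as isopropyl, at this carbon would raise the read-out further or lose it again. They also leave open whether methoxy on the aromatic ring, which made no difference with the methyl-bearing chain, would still make none with the ethyl chain in place.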